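The compounds below may be only part of what the source reports. "The series", "measured", "known", "first", "only" and "open" are said of these compounds alone.

In a functional assay on BXPC-3 cells (Homo sapiens) for inhibition, read by MTT assay, with a stated time of 7 days (a lower number here means a stronger inhibitor, a higher number a weaker inhibitor), compound 1 (`CCN(CC)C(=O)[C@@H]1CCCN(S(=O)(=O)c2ccc(S(=O)(=O)N(CC)CC)cc2)C1`) gives 10500 nM. For the measured compounds named here, compound 2 (`CCN(CC)S(=O)(=O)c1ccc(S(=O)(=O)N2CCC[C@@H](C(=O)NC3CN(C(=O)NC(C)(C)C)C3)C2)cc1`) gives 10100 nM, so the two stand level within the scatter, and compound 1 is a weak starting point with only one measured neighbour.

Compound 3 (`CCN(CC)S(=O)(=O)c1ccc(S(=O)(=O)N2CCC[C@@H](c3cc(C)no3)C2)cc1`) has not yet been measured. It differs from compound 1 at one place: 3-methyl-1,2-oxazol-5-yl in place of diethylcarbamoyl on a saturated ring carbon. In short, it carries 3-methyl-1,2-oxazol-5-yl in place of diethylcarbamoyl on a saturated ring carbon, two ring bonds from the ring nitrogen.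

Going by the values given here, only one measured step bears on this change: a 1.0-fold lower number from compound 1 to compound 2 (0.02 log units; within the scatter). That step replaced diethylamino on the carbonyl carbon with a much larger group and kept the carbonyl, whereas here the whole diethylcarbamoyl leaves, so it is a loose guide. Among the compounds with values here, no measured compound yet lacks that carbonyl. With compound 2 at 10100 nM after that large swap, no step beyond the scatter is expected in either direction, though the uncertainty is wide.

The estimated change is a 1.1-fold lower number from compound 1 to compound 3 (0.02 log units; within the scatter). Compound 3 is therefore expected at about 10000 nM, with an estimated range from 3500 nM to 30000 nM.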

Compound 3, half-maximal inhibitory concentration: 7700 nM
Estimate against measurement, compound 3: 1.3-fold (0.11 log units) above; measured number inside the range.
By their numbers in this assay, from the lowest: compounds 3, 2 and 1 (each within the scatter of the next).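

Taking away the whole diethylcarbamoyl, carbonyl included, and putting 3-methyl-1,2-oxazol-5-yl on the same saturated ring carbon gives a 1.4-fold lower number from compound 1 to compound 3 (0.13 log units; within the scatter) in this assay. This is the first compound shown without that carbonyl, and its loss does not move the number beyond the scatter, so the carbonyl is not required to keep activity at this weak level. Alongside a 1.0-fold lower number from compound 1 to compound 2 (0.02 log units; within the scatter), the step shows that an open amide, a much larger amide and an aromatic five-membered ring can each stand at this place with no difference that can be read, and nothing available explains this flat result.

The compounds shown leave open whether any group on this ring carbon can bring a step beyond the scatter, and a simple amine or a carboxylic acid there would be a sharply different test of that question. They also leave open whether the number responds to changes elsewhere on the shared core, such as a longer chain in place of the ethyl groups on the sulfonamide nitrogen.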